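From Benzyloxycarbonyl to Benzoyl: Compound 1 to Compound 3

The source may hold more compounds than are shown below. What is called first, only, known or untested is meant among the compounds shown, and "the series" means these compounds.

Compound 1 `O=C(CCCSC[C@H](NC(=O)OCc1ccccc1)C(=O)Nc1ccccc1)NO` stands at a limit of the assay rather than at a number: in an assay on Sf9 cells for inhibition of histone deacetylase 8 (Homo sapiens), read by fluorescence, with a stated time of 1 h (on this read-out lower numbers stand for stronger inhibition and higher numbers for weaker inhibition), compound 1 gives > 200 nM. Compound 2 `O=C(CCCSC[C@H](NC(=O)OCc1ccccc1)C(=O)Nc1cccc2ccccc12)NO` likewise gives only a limit in this assay, namely > 200 nM. The step that the two limits leave unreadable from compound 1 to compound 2 cannot be sized because of the limit of > 200 nM in this assay, at which 2 of the 2 values shown sit. Compound 3 `O=C(CCCSC[C@H](NC(=O)c1ccccc1)C(=O)Nc1ccccc1)NO` differs from compound 1 by phenyl in place of benzyloxy on a carbonyl carbon. No measured step touches this change, and the one known step is unreadable, so nothing shown fixes the direction or size of the move. Compound 3 is expected to show a step that the limit leaves unreadable from compound 1 to compound 3, most likely staying near or beyond the limit. Compound 3 is estimated at 600 nM, within 150 nM to 5000 nM.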

Compound 3, half-maximal inhibitory concentration: > 200 nM
Compound 3: a limit, no number; the forecaster's own chance of this, stated with the estimate: 70%; the middle value lies beyond the limit too.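

No step can be read from compound 1 to compound 3, since both stand at a limit rather than at a number: the limit of > 200 nM in this assay, at which 3 of the 3 values shown sit.

On these data alone, how strongly any of the three compounds acts in this assay remains open, as does whether benzoyl or benzyloxycarbonyl gives the stronger inhibition.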